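Methylcarbamoyl in place of methyl in compound 3

A few compounds are considered here, and "the series" means these few. Any claim that something is new, unique, unknown or untested is made for them only; others in the source may bear on it.

Measured in a functional assay on HeLa S3 cells (Homo sapiens) for cytotoxicity, read by MTT assay, with a stated time of 48 h; a lower number here means a stronger inhibitor, a higher number a weaker inhibitor:
- Compound 1 `CCCC/C=C/c1c(C)cc(C)c2[n+]1CC(C)C=C2` gives 370 nM
- Compound 2 `CCCCCCc1c(C)cc(C)c2[n+]1CC(C)C=C2` gives 470 nM
- Compound 3 `CNC(=O)CCCCCc1c(C)cc(C)c2[n+]1CC(C)C=C2` has not yet been measured

Compound 2, at 470 nM, and compound 1, at 370 nM, lie within the scatter of each other in this assay. Compound 3 differs from compound 2 as follows: methylcarbamoyl in place of methyl on a saturated chain carbon, five bonds along the chain from an aromatic carbon. Methylcarbamoyl stands in place of methyl on a saturated chain carbon, five bonds along the chain from an aromatic carbon.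

Within the data shown here, only one measured step alters this chain: a 1.3-fold higher number from compound 1 to compound 2 (0.10 log units; within the scatter). It lies within the scatter, but it swaps hex-1-en-1-yl for hexyl and introduces no methylcarbamoyl. Among the measured compounds shown here, no measured compound carries that group, so the data give no direct size for this change. The expectation is therefore tentative and wide: a moderate move toward a higher number, starting from compound 2 at 470 nM. The expected step is a 3.2-fold higher number from compound 2 to compound 3 (0.50 log units; beyond the scatter). For compound 3 the estimated value is 1500 nM, with an expected range from 400 nM to 6000 nM.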

Compound 3, half-maximal inhibitory concentration: > 30000 nM
Compound 3 ended at the assay's limit; the forecaster's own chance of this, stated with the estimate: 5%; at least 20-fold (1.30 log units) between middle value and limit.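

In this assay, among these compounds, the far end of the chain turns out to matter a great deal, which the earlier compounds gave no sign of: the new step is an at least 63-fold higher number from compound 2 to compound 3 (1.80 log units; beyond the scatter), whereas the only earlier change to this chain, a 1.3-fold higher number from compound 1 to compound 2 (0.10 log units; within the scatter), showed no clear effect. For compound 3 the reading is a limit of the assay and not a number: the limit of > 30000 nM in this assay, at which 1 of the 3 values shown sits. The position on a saturated chain carbon, five bonds along the chain from an aromatic carbon, is therefore not indifferent to substitution, and methylcarbamoyl in place of methyl there is a change this series does not tolerate in this read-out.

The compounds shown leave open which part of the methylcarbamoyl group goes with this drop, since a single group was placed here and the amide hydrogen, the carbonyl and the added length all enter together. Whether a longer plain alkyl chain, a methyl ester, a carboxylic acid or an amine at this place would read like compound 2 or like compound 3 remains unanswered, as does the effect of moving the amide closer along the chain, as in 2-(methylcarbamoyl)ethyl.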